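The source may report more compounds than this note shows. Statements on the series, on what has been measured and on what is new or still open speak of the compounds shown alone.

Measured so far:
Compound 1 (`COc1ncc(-c2ccc3c(c2)N(c2ccc(C)cc2)C(=O)CO3)cc1NS(=O)(=O)c1ccc(F)cc1`) gives 4650 nM as a number
Compound 2 (`O=C1COc2ccc(-c3cnc(Cl)c(NS(=O)(=O)c4ccc(F)cc4)c3)cc2N1c1ccc(F)cc1`) gives > 40000 nM as a limit
Compound 3 (`COc1cccc(N2C(=O)COc3ccc(-c4ccc(O)cc4)cc32)c1`) gives > 40000 nM as a limit

Compound 1 is the only one of the three with a number in a functional assay on HeLa cells (Homo sapiens) for antiproliferative activity, read by MTT assay, with a stated time of 72 h (on this read-out higher numbers stand for weaker inhibition and lower numbers for stronger inhibition), and so has no measured neighbour to be ranked against. The other two values are limits (the limit of > 40000 nM in this assay, at which 2 of the 3 values shown sit).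

Compound 4 (`COc1ncc(-c2ccc3c(c2)N(C2CC2)C(=O)CO3)cc1NS(=O)(=O)c1ccc(F)cc1`) keeps the core of compound 1, with cyclopropyl in place of 4-methylphenyl on an amide-type nitrogen in a ring. For the measured compounds named here, no measured step covers this change, so the expectation is loose. In this assay a modest move toward weaker inhibition is expected, estimated as a 2.2-fold higher number from compound 1 to compound 4 (0.33 log units; beyond the scatter) and with a step within the scatter still possible. The estimated value for compound 4 is 10000 nM (expected range 2000 nM to 40000 nM).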

Compound 4, half-maximal inhibitory concentration: 6030 nM
Beside the measured number, compound 4's estimate is 1.7-fold (0.22 log units) above it; the measured number falls inside the stated range.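

In this assay, this is the first step shown at the amide-type nitrogen in a ring: a 1.3-fold higher number from compound 1 to compound 4 (0.11 log units; within the scatter). For this pair, cyclopropyl with 3 heavy atoms sits within the scatter of 4-methylphenyl with 7 heavy atoms, so a six-membered aromatic ring on this nitrogen is not needed to hold the value. Nothing shown bears on a cause for this step. Still open, from the compounds shown here alone, is how an aminoethyl chain or a carboxylic acid on this nitrogen would read in this assay.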